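Swapping the fluoro-methylphenyl isomer on the shared core

The source may hold more compounds than are shown below. What is called first, only, known or untested is meant among the compounds shown, and "the series" means these compounds.

In a functional assay on KBVIN cells (Homo sapiens) for antiproliferative activity, read by sulforhodamine B assay, with a stated time of 3 days (a higher number here means that more compound is needed for the effect, a lower number that less compound is needed), compound 1 `CCC1=C(O)c2c(oc(-c3ccc(SC)cc3)cc2=O)C(CC)(CC)C1=O` gives 1.38 uM and compound 2 `CCC1=C(O)c2c(oc(-c3cc(C)ccc3F)cc2=O)C(CC)(CC)C1=O` gives 3.24 uM, so compound 2 holds the higher of the two numbers. Compound 3 `CCC1=C(O)c2c(oc(-c3ccc(F)c(C)c3)cc2=O)C(CC)(CC)C1=O` is not yet measured. It carries 4-fluoro-3-methylphenyl in place of 2-fluoro-5-methylphenyl on an aromatic carbon next to the ring oxygen: 4-fluoro-3-methylphenyl in place of 2-fluoro-5-methylphenyl on an aromatic carbon. Going by the values given here, one measured step bears on this change: a 2.3-fold higher number from compound 1 to compound 2 (0.37 log units; beyond the scatter), a modest rise on the entry of 2-fluoro-5-methylphenyl at that same place. Among the compounds with values here, no measured step yet compares two isomers, so the guidance is thin. With that group gone, a small return toward compound 1 at 1.38 uM is expected, possibly within the scatter. The expected step is a 1.4-fold lower number from compound 2 to compound 3 (0.15 log units; within the scatter). The estimate for compound 3 is 2.3 uM, with an expected range of 1 uM to 5 uM.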

Compound 3, concentration for half-maximal effect: 1.62 uM
Compound 3: middle estimate off by 1.4-fold (0.15 log units), on the high side, within the range that was stated.
By their numbers in this assay, from the lowest: compounds 1, 3 and 2 (each within the scatter of the next, the first and the last beyond it).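

Going by these compounds alone, at this aromatic carbon next to the ring oxygen, the first comparison of two isomers shows a step within the scatter in this assay for 4-fluoro-3-methylphenyl in place of 2-fluoro-5-methylphenyl (a 2.0-fold lower number from compound 2 to compound 3 (0.30 log units; within the scatter)). The change from 4-(methylsulfanyl)phenyl to 4-fluoro-3-methylphenyl also stays within the scatter (a 1.2-fold higher number from compound 1 to compound 3 (0.07 log units; within the scatter)), so the earlier rise (a 2.3-fold higher number from compound 1 to compound 2 (0.37 log units; beyond the scatter)) does not extend to every fluoro-methylphenyl group at this place, and only compound 1 and compound 2 stand apart. No supporting data bear on why the two isomers compare as they do.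

All three groups shown are uncharged phenyl rings without hydrogen-bond donors or acceptors. As far as these compounds go, how this position responds to a phenyl ring carrying an amine or a carboxylic acid remains open, as does the effect of other arrangements of the fluoro and methyl groups.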